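A few compounds are considered here, and "the series" means these few. Any claim that something is new, unique, unknown or untested is made for them only; others in the source may bear on it.

In an ADME assay on Caco-2 cells (Homo sapiens) for permeability, in the apical to basolateral direction, at pH 7.4 (on this read-out lower numbers stand for lower permeability and higher numbers for higher permeability), compound 1 `Cc1ccc2[nH]c(C(=O)N[C@H]3CN(S(=O)(=O)c4ccccc4)C[C@@H]3C(=O)N[C@@H]3CCCN(C)C3)cc2c1` gives 0.76 10^-6 cm/s, while compound 2 `Cc1ccc2[nH]c(C(=O)N[C@H]3CN(S(=O)(=O)c4ccccc4)C[C@@H]3C(=O)N[C@H]3CCCNC3)cc2c1` gives 0.04 10^-6 cm/s, the lower of the two numbers. Compound 3 `O=C(N[C@H]1CN(S(=O)(=O)c2ccccc2)C[C@@H]1C(=O)N[C@H]1CCCNC1)c1cc(-c2ccc(Cl)cc2)on1` keeps the piperidin-3-yl of compound 2 and differs from it by 5-(4-chlorophenyl)-1,2-oxazol-3-yl in place of 5-methyl-1H-indol-2-yl on a carbonyl carbon. Among the compounds with values here, the one measured step is a 19-fold lower number from compound 1 to compound 2 (1.28 log units; beyond the scatter), which is large and beyond the scatter. That step, however, is piperidin-3-yl in place of 1-methylpiperidin-3-yl on an amide-type nitrogen, so it lies elsewhere in the molecule and gives no direct size for the new change. Within the data shown here, no measured pair tests a replacement on the carbonyl carbon. The expectation therefore starts from compound 2 at 0.04 10^-6 cm/s, with a wide margin on both sides for the untested change. The estimate means a 1.5-fold higher number from compound 2 to compound 3 (0.18 log units; within the scatter), and no step beyond the scatter is expected in this assay. For compound 3 the expected value is 0.06 10^-6 cm/s, with an estimated range of 0.02 10^-6 cm/s to 0.25 10^-6 cm/s.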

Compound 3, apparent permeability: < 0.01 10^-6 cm/s
Compound 3 ended at the assay's limit (the forecaster's own chance of this, stated with the estimate: 15%); middle value at least 6.0-fold (0.77 log units) from the limit.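

In this assay, the place on the carbonyl carbon also moves the read-out: 5-(4-chlorophenyl)-1,2-oxazol-3-yl in place of 5-methyl-1H-indol-2-yl gives an at least 4.0-fold lower number from compound 2 to compound 3 (0.60 log units; beyond the scatter). The earlier pair had shown a change only on the amide-type nitrogen, whereas here the piperidin-3-yl stays fixed and the step still lies beyond the scatter, so a second place in the molecule matters for this read-out. Going by these compounds, compound 3 sits at a limit and not at a number, so this step fixes only a smallest size, and how far the true value lies past that limit stays unknown: the limit of < 0.01 10^-6 cm/s in this assay, at which 1 of the 3 values shown sits.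

The entering group differs from the leaving one in its five-membered ring, its hetero atoms, its hydrogen-bond count and its chlorine all at once, so the compounds shown cannot assign the step to any one of these features. On these data alone, it also stays open how a 5-phenyl-1,2-oxazol-3-yl without the chlorine, or a 5-methoxy-1H-indol-2-yl, would read on the same carbonyl carbon, and whether the 1-methylpiperidin-3-yl of compound 1 would lift compound 3 from the limit.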